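Swapping the amide-bearing alkene for a benzamide ring

This account rests on a few compounds, and the source may have more. Where it says the series, first, only, none or still open, it means among the compounds named here.

Measured compounds:
compound 1 `CNC(=O)/C=C/c1ccc(NC(=O)Nc2ccc(Cl)c(C(F)(F)F)c2)cc1` — 20400 nM
compound 2 `CNC(=O)/C(C)=C/c1ccc(NC(=O)Nc2ccc(Cl)c(C(F)(F)F)c2)cc1` — 44300 nM

Both compounds share a diaryl urea core and were tested in a functional assay on HepG2 cells (Homo sapiens) for inhibition, read by MTT assay, with a stated time of 120 h; on this read-out lower numbers stand for stronger inhibition and higher numbers for weaker inhibition. Compound 2 stands highest of the two numbers; its nearest neighbour is compound 1, and the step of a 2.2-fold higher number from compound 1 to compound 2 (0.34 log units; beyond the scatter) came with a single added methyl on the chain.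

Compound 3 `CNC(=O)c1cccc(-c2ccc(NC(=O)Nc3ccc(Cl)c(C(F)(F)F)c3)cc2)c1` replaces that chain altogether: 3-(methylcarbamoyl)phenyl in place of 2-(methylcarbamoyl)prop-1-en-1-yl on an aromatic carbon. For the measured compounds named here, only one measured step exists, from compound 1 to compound 2, and it concerns a methyl on the open chain rather than an exchange of the chain for a ring, so it bears on this change only loosely. It shows that small edits to this part of the molecule move this assay by a modest amount, not by large jumps.

For compound 3 a number somewhat lower than that of compound 2 is therefore expected, with wide uncertainty: 12000 nM (range 3000 nM to 50000 nM). The expected step is a 3.7-fold lower number from compound 2 to compound 3 (0.57 log units; beyond the scatter).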

Compound 3, half-maximal inhibitory concentration: 37100 nM
Compound 3: middle estimate off by 3.1-fold (0.49 log units), on the low side; low and high end bracket the measured number.
By their numbers in this assay, from the lowest: compounds 1, 3 and 2 (each within the scatter of the next, the first and the last beyond it).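

The new result shows that this position, on an aromatic carbon para to a large group, can carry a whole six-membered aromatic ring in place of an open chain without a change that this read-out can resolve: in this assay, 3-(methylcarbamoyl)phenyl in place of 2-(methylcarbamoyl)prop-1-en-1-yl gives a 1.2-fold lower number from compound 2 to compound 3 (0.08 log units; within the scatter), and 3-(methylcarbamoyl)phenyl in place of 2-(methylcarbamoyl)ethenyl gives a 1.8-fold higher number from compound 1 to compound 3 (0.26 log units; within the scatter). Both steps lie within the scatter, so compound 3 cannot be told apart from either chain compound, even though the step between those two chain compounds lies just beyond it. No measurement shown explains why exchanging the chain for the ring leaves the number so little moved.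

On these data alone, what remains open is whether the methylcarbamoyl group matters at all at this position, since a carboxylic acid or an amine in its place could show whether the number depends on that group. As far as these compounds go, it is also open whether a saturated cyclohexane ring or a longer chain carrying the same methylcarbamoyl group would stay in this same range in this assay.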